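The source may report more compounds than this note shows. Statements on the series, on what has been measured and on what is new or still open speak of the compounds shown alone.

In a functional assay for antagonist activity at Alpha-1A adrenergic receptor (Oryctolagus cuniculus) (a higher number here means weaker binding, a lower number tighter binding), compound 1 `CN(C)C(=O)c1cccnc1NCCCN1CCN(c2ccccc2OC(F)(F)F)CC1` gives 3.16 nM, compound 2 `CN(C)C(=O)c1cccnc1NCCCN1CCN(c2ccccc2OCC(F)(F)F)CC1` gives 0.1 nM and compound 3 `CN(C)C(=O)c1cccnc1NCCCN1CCN(c2ccccc2-c2ncco2)CC1` gives 0.316 nM; compound 3 therefore stands second highest of the three numbers, with a 3.2-fold higher number from compound 2 to compound 3 (0.50 log units; beyond the scatter) and a 10-fold lower number from compound 1 to compound 3 (1.00 log units; beyond the scatter). Compound 4 `CN(C)C(=O)c1cccnc1NCCCN1CCN(c2ccccc2C2CC2)CC1` differs from compound 3 by cyclopropyl in place of 1,3-oxazol-2-yl on an aromatic carbon. Both measured steps at this aromatic carbon bear on it: a 10-fold lower number from compound 1 to compound 3 (1.00 log units; beyond the scatter) and a 3.2-fold higher number from compound 2 to compound 3 (0.50 log units; beyond the scatter) show that exchanging the group here moves this assay by modest amounts in either direction. Among the measured compounds shown here, no measured step covers a group without hydrogen-bond acceptors at this position, so the expectation rests on the spread seen so far; a modest rise in this assay is expected, a 3.2-fold higher number from compound 3 to compound 4 (0.50 log units; beyond the scatter). Compound 4 is expected to give 1 nM, within 0.25 nM to 4 nM.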

Compound 4, dissociation constant: 0.631 nM
Estimate against measurement, compound 4: 1.6-fold (0.20 log units) above; the range from low to high includes it.
By their numbers in this assay, from the lowest: compound 2; then compounds 3 and 4 (each within the scatter of the next); then compound 1.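

Cyclopropyl, with 0 hydrogen-bond acceptors, is not told apart from 1,3-oxazol-2-yl, with 2 hydrogen-bond acceptors, in this assay given a 2.0-fold higher number from compound 3 to compound 4 (0.30 log units; within the scatter) so acceptors on this group are not needed for a number in this range. Compound 4 stands apart from both oxygen-linked groups, with a 6.3-fold higher number from compound 2 to compound 4 (0.80 log units; beyond the scatter) and a 5.0-fold lower number from compound 1 to compound 4 (0.70 log units; beyond the scatter) so 2,2,2-trifluoroethoxy and trifluoromethoxy remain the two ends of the series. Nothing available explains these steps.

Going by these compounds, whether an amine or a carboxylic acid on this aromatic carbon would stay inside that span remains open.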